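Ethylamino gives way to dipropylamino

This account rests on a few compounds, and the source may have more. Where it says the series, first, only, none or still open, it means among the compounds named here.

In a functional assay on the whole organism for positive allosteric modulation, with Mus musculus as the target (a lower number here means that less compound is needed, a higher number that more compound is needed for the effect), the compounds measured so far read:
- compound 1 `CCC(=O)N(c1ccc(Cl)cc1)C1CCCCC1N(C)C` gives 35 mg/kg
- compound 2 `CCNC1CCCC1N(C(=O)CC)c1ccc(Cl)c(Cl)c1` gives 0.2 mg/kg

Compound 2 holds the lower of the two numbers, and its gap to compound 1 lies beyond the scatter. Compound 3 `CCCN(CCC)C1CCCC1N(C(=O)CC)c1ccc(Cl)c(Cl)c1` has dipropylamino in place of ethylamino on a saturated ring carbon. Going by the values given here, no measured pair shows this change alone, so the expectation is a judgement with a wide range. In this assay the number is expected to rise beyond the scatter, an estimated step of a 20-fold higher number from compound 2 to compound 3 (1.30 log units; beyond the scatter) in size. The estimate for compound 3 is 4 mg/kg with an expected range from 0.6 mg/kg to 30 mg/kg overall.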

Compound 3, dose for half-maximal effect: 2 mg/kg
Compound 3: the middle estimate sits 2.0-fold (0.30 log units) above what was measured; low and high end bracket the measured number.
By their numbers in this assay, from the lowest: compound 2; then compound 3; then compound 1.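

Dipropylamino in place of ethylamino on a saturated ring carbon gives a 10-fold higher number from compound 2 to compound 3 (1.00 log units; beyond the scatter) in this assay and so provides the first reading of this position with the rest of the molecule unchanged. The exchange adds carbon and removes the hydrogen-bond donor at once, and this single pair cannot separate those two differences. Nothing available explains the rise in the number.

The compounds shown leave open whether propylamino, which retains a hydrogen-bond donor, or diethylamino, which has none, would fall nearer compound 2 or compound 3.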